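This account rests on a few compounds, and the source may have more. Where it says the series, first, only, none or still open, it means among the compounds named here.

Measured so far in an assay on isolated protein for displacement of a labelled ligand from acyl-CoA:cholesterol acyltransferase (Oryctolagus cuniculus); a higher number here means a weaker inhibitor, a lower number a stronger inhibitor:
compound 1 `CC(C)c1cccc(C(C)C)c1NC(=O)Nc1nc2ccccc2n1-c1ccccc1Br`: 22 nM
compound 2 `CC(C)c1cccc(C(C)C)c1NC(=O)Nc1nc2ccccc2n1-c1c(Cl)cccc1Cl`: 11 nM
compound 3 `CC(C)c1cccc(C(C)C)c1NC(=O)Nc1nc2ccccc2n1-c1ccccc1N(C)C`: 41 nM

Compound 3 carries the highest of the three numbers. Its nearest neighbour is compound 1, with a 1.9-fold higher number from compound 1 to compound 3 (0.27 log units; within the scatter), which stays within the scatter; its furthest is compound 2, with a 3.7-fold higher number from compound 2 to compound 3 (0.57 log units; beyond the scatter), a modest step beyond the scatter.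

Compound 4 `CC(C)c1cccc(C(C)C)c1NC(=O)Nc1nc2ccccc2n1-c1ncccc1Cl` is not yet measured. The change from compound 3 is 3-chloropyridin-2-yl in place of 2-(dimethylamino)phenyl on an aromatic nitrogen.

For the measured compounds named here, two measured steps bear on this. The step from a bromo-bearing ring to the dimethylamino-bearing ring, a 1.9-fold higher number from compound 1 to compound 3 (0.27 log units; within the scatter), was within the scatter; the step from the dichloro-bearing ring, a 3.7-fold higher number from compound 2 to compound 3 (0.57 log units; beyond the scatter), was beyond it. Compound 4 returns to a ring carrying a chloro group, though now a pyridine rather than a benzene ring, for which no measured comparison exists. A lower number than compound 3 is therefore expected, of roughly the size of those two steps in reverse, a 2.6-fold lower number from compound 3 to compound 4 (0.41 log units; beyond the scatter), landing near compound 1 and compound 2. For compound 4 in this assay the estimate is 16 nM, with a range of 6 nM to 45 nM.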

Compound 4, half-maximal inhibitory concentration: 100 nM
For compound 4 the middle estimate is 6.3-fold (0.80 log units) below the measured one; measured number outside the range, above it.
By their numbers in this assay, from the lowest: compounds 2, 1 and 3 (each within the scatter of the next, the first and the last beyond it); then compound 4.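

In this assay the 3-chloropyridin-2-yl group on the aromatic nitrogen gives a higher number than each of the three groups whose ring is of carbon only: a 2.4-fold higher number from compound 3 to compound 4 (0.39 log units; beyond the scatter), a 4.5-fold higher number from compound 1 to compound 4 (0.66 log units; beyond the scatter) and a 9.1-fold higher number from compound 2 to compound 4 (0.96 log units; beyond the scatter). For the compounds shown here, a chloro group on the ring therefore does not by itself keep the number low at this position, and the widest of these steps, the one from compound 2, also takes away a second chloro group. Nothing measured accounts for the higher number of compound 4.

How much of the rise belongs to the ring nitrogen remains open, since a 2-chlorophenyl group, which would separate the ring nitrogen from the chloro pattern, is absent from the compounds shown. From the compounds shown here alone, whether a methoxy group or an amine on the 3-position of the same pyridine ring would lower the number also stays open.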